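The source may hold more compounds than are shown below. What is called first, only, known or untested is meant among the compounds shown, and "the series" means these compounds.

Measured compounds:
compound 1 `COc1ccc2nc(-c3ccccc3OCc3ccccc3)sc2c1` — 4300 nM
compound 2 `COc1ccc2nc(-c3cccc(NC(C)=O)c3)sc2c1` — 1900 nM

Both compounds share one core and differ only in the aryl group attached to it. In an assay on isolated protein for inhibition of Luciferin 4-monooxygenase (Photuris pensylvanica), read by a luciferase reporter (on this read-out lower numbers stand for stronger inhibition and higher numbers for weaker inhibition), compound 1 gives 4300 nM, while compound 2 gives 1900 nM. Compound 2 therefore holds the lowest of the two numbers; compound 1 stands somewhat above it, and the gap between the two lies beyond the usual scatter. Among the measured compounds shown here, no pair of measured compounds differs in a single place, so no single-change step in this assay is known yet.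

Compound 3 `COc1ccc2nc(-c3cccc(C)c3)sc2c1` is the next compound to be measured. It keeps the core of compound 2 and differs from it in one place: methyl in place of acetamido on an aromatic carbon, meta to a large group. For the measured compounds named here, with no measured single-change step to lean on, the expectation rests on compound 2 alone. A step in this assay toward weaker inhibition is expected, of a size a little beyond the scatter rather than a large one. The step from compound 2 to compound 3 that this estimate implies is a 2.1-fold higher number from compound 2 to compound 3 (0.32 log units; beyond the scatter), and it is an estimate only. Compound 3 is expected to give 4000 nM in this assay, with a range from 1300 nM to 14000 nM.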

Compound 3, half-maximal inhibitory concentration: 670 nM
Estimate against measurement, compound 3: 6.0-fold (0.78 log units) above; measured number below the stated range.
By their numbers in this assay, from the lowest: compound 3; then compound 2; then compound 1.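

In this assay, this aromatic carbon now has its first single-change step, with methyl in place of acetamido: a 2.8-fold lower number from compound 2 to compound 3 (0.45 log units; beyond the scatter), a modest step beyond the scatter. At this position, therefore, the acetamido group with its hydrogen-bond donor and acceptor is not required for inhibition, and a single carbon gives the lower number of this pair. No measurement at hand bears on why the two groups differ, so the step stays a bare observation.

One pair cannot separate the removal of the acetamido group from the addition of methyl: hydrogen, ethyl, methoxy, an amine and a carboxylic acid at this same carbon are not among the compounds shown. Also open, going by these compounds, is whether methyl gives a similar step elsewhere on the aryl ring, and compound 1 cannot answer this, as it differs from compound 3 in more than one place.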